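This account rests on a few compounds, and the source may have more. Where it says the series, first, only, none or still open, it means among the compounds named here.

Within the data shown here, in an ADME assay on a cell-free system (plasma, Rattus norvegicus) for protein binding (on this read-out lower numbers stand for a smaller free fraction and higher numbers for a larger free fraction), two compounds on one shared core have numbers so far. Compound 1 (`Cc1c(C(F)F)nnc2sc(C(=O)NC3CN(c4ncc(C(F)(F)F)cn4)C3)c(N)c12`) gives 0.017 as its reading, and compound 2 (`COc1nnc2sc(C(=O)NC3CN(c4ncc(C(F)(F)F)cn4)C3)c(N)c2c1C`) gives 0.018 as its reading. Among the measured compounds shown here, compound 2 therefore stands within the scatter of compound 1, its only neighbour on this scale.

Compound 3 (`Cc1c(Cl)nnc2sc(C(=O)NC3CN(c4ncc(C(F)(F)F)cn4)C3)c(N)c12`) keeps the shared core and changes one group (chloro in place of methoxy on an aromatic carbon), with chloro in place of methoxy on an aromatic carbon, next to the ring nitrogen and ortho to a methyl group. For the measured compounds named here, one measured step bears on this change, the one (a 1.1-fold higher number from compound 1 to compound 2 (0.02 log units; within the scatter)) that put methoxy in place of difluoromethyl on an aromatic carbon. That exchange of one group produced no shift beyond the scatter in this assay for these two compounds. Going by the values given here, no measured compound carries chloro, however, so the basis is thin. No step beyond the scatter is expected, and no direction can be called with confidence. The expected step (a 1.1-fold lower number from compound 2 to compound 3 (0.05 log units; within the scatter)) stays inside the usual scatter. For compound 3 the estimate is 0.016 as a middle value, with an expected range from 0.008 to 0.03 across repeat measurements.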

Compound 3, unbound fraction: 0.022
Compound 3: the middle estimate sits 1.4-fold (0.14 log units) below what was measured; measured number inside the range.
By their numbers in this assay, from the lowest: compounds 1, 2 and 3 (each within the scatter of the next).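

At this position, next to the ring nitrogen and ortho to a methyl group, this assay now has readings for three different groups: difluoromethyl, methoxy and chloro. Putting chloro, with no hydrogen-bond acceptor, in place of methoxy, with one, gives a step that stays within the scatter (a 1.2-fold higher number from compound 2 to compound 3 (0.09 log units; within the scatter)), and chloro in place of difluoromethyl does the same (a 1.3-fold higher number from compound 1 to compound 3 (0.11 log units; within the scatter)), so all three exchanges among these compounds leave the unbound fraction inside the usual scatter of repeated measurements. Nothing available on these compounds accounts for this lack of a clear shift.

These three groups alone cannot show whether this position would tolerate every exchange, and an amine, a carboxylic acid or a longer chain in the same place could still move the number beyond the scatter. All three compounds also keep the rest of the shared core unchanged, so how the unbound fraction responds to changes elsewhere on the molecule remains an open question.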